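A few compounds are considered here, and "the series" means these few. Any claim that something is new, unique, unknown or untested is made for them only; others in the source may bear on it.

Measured so far in a functional assay on NCI-H157 cells (Homo sapiens) for antiproliferative activity, read by sulforhodamine B assay, with a stated time of 48 h, tested at 1 uM (a higher number here means more inhibition of growth at the concentration tested, a lower number less inhibition of growth), on this series:
- compound 1 (`Fc1ccc(OCc2nn3c(-c4ccncc4)nnc3s2)cc1`) gives 25.6%
- compound 2 (`c1ccc2c(C3=Nn4c(nnc4-c4ccncc4)SC3)cccc2c1`) gives 59.9%

Compound 1 holds the lower of the two numbers, and compound 2 stands above it, beyond the scatter. These two compounds differ in more than one place, so their gap says nothing about any single exchange.

Still unmeasured is compound 3 (`Oc1ccc(OCc2nn3c(-c4ccncc4)nnc3s2)cc1`), which keeps the core of compound 1. The change is hydroxy in place of fluoro on an aromatic carbon and amounts to hydroxy in place of fluoro on an aromatic carbon, para to a large group.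

Among the measured compounds shown here, no measured pair shows this exchange, so the data give no direct guide to its size in this assay. For the measured compounds named here, the expectation is a step within the scatter, if anything slightly upward, anchored on compound 1 at 25.6% as the only close neighbour. The estimated move is a number 2.4 percentage points higher from compound 1 to compound 3 (within the scatter) and nothing beyond the scatter is expected. For compound 3 the expected value is 28% with an estimated range from 10% to 48% at this stage.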

Compound 3, percent growth inhibition at one concentration: 56.3%
Estimate against measurement, compound 3: 28.3 percentage points below, and the stated range ends below it.
By their numbers in this assay, from the lowest: compound 1; then compounds 3 and 2 (each within the scatter of the next).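

In this assay the change from 4-fluorophenyl to 4-hydroxyphenyl on the core of compound 1 gives a number 30.7 percentage points higher from compound 1 to compound 3 (beyond the scatter) and counts as a large step, so the replacement of one heavy atom at this place on the aromatic ring is enough to move the growth inhibition well beyond the scatter. The earlier compounds shown here differ in more than one place and could not show this; here the change is isolated, with the entering hydroxy counted as one hydrogen-bond donor and one hydrogen-bond acceptor, and the leaving fluoro counted as neither. No available measurement bears on the origin of this step, which stands as an observation on a single pair.

Open, from the compounds shown here alone, is whether the step is specific to hydroxy, which an amine or a methoxy group at the same place, para to a large group, would help to settle. Also open is whether the same exchange gives a step of similar size on any other member of the series, as this pair is the only one shown that carries it.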